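One Substituent Swap on the Shared Core

The source may hold more compounds than are shown below. What is called first, only, known or untested is meant among the compounds shown, and "the series" means these compounds.

Compound 1: `CCS[C@@H]1[C@H](SCC)[C@@H](Cn2cc(-c3ccccc3C(F)(F)F)nn2)O[C@H]1n1ccc(=O)[nH]c1=O` — 32800 nM
Compound 2: `CCS[C@@H]1[C@H](SCC)[C@@H](Cn2cc(COC(C)=O)nn2)O[C@H]1n1ccc(=O)[nH]c1=O` — >= 100000 nM

Within the data shown here, in a functional assay on HeLa cells (Homo sapiens) for cytotoxicity, read by MTT assay, with a stated time of 72 h (a lower number here means that less compound is needed, a higher number that more compound is needed for the effect), compound 1 gives 32800 nM, the only number among the values shown. Compound 2 reaches only a limit of this assay, >= 100000 nM. Among the measured compounds shown here, the single measured step, an at least 3.0-fold higher number from compound 1 to compound 2 (0.48 log units; beyond the scatter), rests on (the limit of >= 100000 nM in this assay, at which 1 of the 2 values shown sits), so its full size is not known. Compound 3, `CCS[C@@H]1[C@H](SCC)[C@@H](Cn2cc(-c3cccs3)nn2)O[C@H]1n1ccc(=O)[nH]c1=O`, has not yet been measured. It differs from compound 1 as follows: thiophen-2-yl in place of 2-(trifluoromethyl)phenyl on an aromatic carbon. The measured step bears on this change only loosely: it alters the same group on the same aromatic carbon, but compound 2 carries acetoxymethyl there, whereas compound 3 keeps an aromatic ring in that position. For compound 3 a step of a 1.4-fold higher number from compound 1 to compound 3 (0.14 log units; within the scatter) is therefore expected, toward a higher number but short of the limit that compound 2 met. The estimate for compound 3 is 45000 nM, within a range of 15000 nM to 130000 nM.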

Compound 3, half-maximal effective concentration: >= 100000 nM
Compound 3: no number, only a limit; the forecaster's own chance of this, stated with the estimate: 30%; at least 2.2-fold (0.34 log units) between middle value and limit.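

Replacing 2-(trifluoromethyl)phenyl with thiophen-2-yl gives an at least 3.0-fold higher number from compound 1 to compound 3 (0.48 log units; beyond the scatter) in this assay, so keeping an aromatic ring on this carbon is not enough on its own to retain a measurable number. Among these compounds, compound 2, with acetoxymethyl, and compound 3, with thiophen-2-yl, both end at a limit of this assay, which leaves 2-(trifluoromethyl)phenyl as the only one of the three groups with a number. The step between compound 2 and compound 3 cannot be read, and the full size of the steps from compound 1 stays unknown because they rest on a limit: the limit of >= 100000 nM in this assay, at which 2 of the 3 values shown sit.

The compounds shown leave open whether the number of compound 1 depends on the trifluoromethyl group or on the phenyl ring itself, a question that unsubstituted phenyl or 2-methylphenyl here would address. They also do not show how an amine or a carboxylic acid at this position would read.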